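Aminocyclohexyl replacement on the anilinic nitrogen of compound 1

This account rests on a few compounds, and the source may have more. Where it says the series, first, only, none or still open, it means among the compounds named here.

Among the compounds with values here, compound 1 `Nc1ccc(Nc2c(C(=O)NCc3ccc(F)cc3)nc(Br)c3cccnc23)cc1` is the only member of this series with a number in a functional assay on MCF7 cells (Homo sapiens) for cytotoxicity, read by MTT assay, with a stated time of 72 h (a lower number here means a stronger inhibitor, a higher number a weaker inhibitor), where compound 1 gives 4000 nM. Compound 2 `N[C@H]1CC[C@H](NC(=O)c2nc(Br)c3cccnc3c2NCc2ccc(F)cc2)CC1` carries the same core with the groups on the two nitrogens exchanged, and in this assay compound 2 stands as "not determined" (no result reported). Compound 3 `N[C@H]1CC[C@H](Nc2c(C(=O)NCc3ccc(F)cc3)nc(Br)c3cccnc23)CC1` differs from compound 1 in one place: 4-aminocyclohexyl in place of 4-aminophenyl on a nitrogen on an aromatic ring. With no measured step between compounds shown, the expectation rests on compound 1 alone. The step of a 1.3-fold higher number from compound 1 to compound 3 (0.10 log units; within the scatter) is expected to stay within the usual scatter. Compound 3 is therefore estimated at 5000 nM, between 1500 nM and 16000 nM.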

Compound 3, half-maximal inhibitory concentration: 2000 nM
Estimate against measurement, compound 3: 2.5-fold (0.40 log units) above; low and high end bracket the measured number.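

In this assay, 4-aminocyclohexyl in place of 4-aminophenyl on this nitrogen gives a 2.0-fold lower number from compound 1 to compound 3 (0.30 log units; within the scatter) and so does not separate the two compounds. In this pair, a non-aromatic carbon ring with 2 defined stereocentres can stand where the aromatic carbon ring stood, without a change beyond the scatter. Nothing at hand gives a reason for this result.

Open, from the compounds shown here alone, is whether the amine of either ring matters here. A hydroxyl in its place, or a longer aminoalkyl chain on this nitrogen, would address that.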